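The compounds below may be only part of what the source reports. "The series", "measured", "known", "first", "only" and "open" are said of these compounds alone.

For the measured compounds named here, compound 1 `CC[C@@]1(O)[C@@H](CO)O[C@@H](n2ccc(N)nc2=O)[C@@H]1O` is the only compound here with a number rather than a limit: in a functional assay on KB cells (Homo sapiens), read by MTT assay (on this read-out higher numbers stand for weaker inhibition and lower numbers for stronger inhibition), compound 1 gives 258000 nM. Compound 2 `C#C[C@H]1[C@@H](O)[C@H](n2ccc(=O)[nH]c2=O)O[C@@H]1CO` gives > 350000 nM in this assay, which is a limit of the assay and not a number. Compound 2 thus sits at the limit of > 350000 nM in this assay, at which 1 of the 2 values shown sits, in this assay. Compound 3 `C#CC[C@@]1(O)[C@@H](CO)O[C@@H](n2ccc(N)nc2=O)[C@@H]1O` differs from compound 1 by ethynyl in place of methyl on a saturated chain carbon bound to a saturated ring carbon. Going by the values given here, no step between two measured compounds is available to guide this change, so in this assay a step within the usual scatter, in either direction, is expected. Compound 3 is therefore expected to give 230000 nM, between 70000 nM and 350000 nM. The estimated step of a 1.1-fold lower number from compound 1 to compound 3 (0.05 log units; within the scatter) is expected to be small.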

Compound 3, half-maximal inhibitory concentration: > 350000 nM
Compound 3 was reported as a limit; the forecaster's own chance of this, stated with the estimate: 35%; middle value at least 1.5-fold (0.18 log units) from the limit.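

In this assay, ethynyl in place of methyl on a saturated chain carbon bound to a saturated ring carbon gives an at least 1.3-fold higher number from compound 1 to compound 3 (0.13 log units; that floor lies within the scatter). The value of compound 3 is a limit of the assay, so this step is only a floor, and the true size of the change cannot be read. Compound 3 therefore adds a second compound at this limit: the limit of > 350000 nM in this assay, at which 2 of the 3 values shown sit.

Going by these compounds, whether propyl, an amine or a carboxylic acid at this place would shift the number of compound 1 stays open. For the compounds shown here, compound 2 differs from compound 1 in more than one place, so no step between them can be read.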